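Bis-benzimidazole series: cytotoxicity against a leukemia cell line

The source may hold more compounds than are shown below. What is called first, only, known or untested is meant among the compounds shown, and "the series" means these compounds.

Measured so far:
compound 1 `N#Cc1ccc2[nH]c(-c3ccc4[nH]c(-c5ccccc5)nc4c3)nc2c1` — > 25000 nM
compound 2 `NC(=O)c1ccc2[nH]c(-c3ccc4[nH]c(-c5ccccc5)nc4c3)nc2c1` — > 25000 nM

In a functional assay on RPMI 8402 cells (Homo sapiens) for cytotoxicity (on this read-out higher numbers stand for weaker inhibition and lower numbers for stronger inhibition), compound 1 gives only > 25000 nM, a limit of the assay and not a number. Compound 2 likewise ends at the limit > 25000 nM. The step that the two limits leave unreadable from compound 1 to compound 2 is therefore not readable, since the limit of > 25000 nM in this assay, at which 2 of the 2 values shown sit, holds both values. Compound 2 thus stands at the limit, with no measured number to place it. Compound 3 `CN1CCN(c2ccc3[nH]c(-c4ccc5[nH]c(-c6ccccc6)nc5c4)nc3c2)CC1` carries 4-methylpiperazin-1-yl in place of carbamoyl on an aromatic carbon. Among the measured compounds shown here, no measured step bears on this change, so neither direction nor size of the step can be drawn from the two limits in this assay. Compound 3 is estimated at 8000 nM, expected between 800 nM and 40000 nM. The expected step is an at least 3.1-fold lower number from compound 2 to compound 3 (0.49 log units; beyond the scatter).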

Compound 3, half-maximal inhibitory concentration: 490 nM
Estimate against measurement, compound 3: 16-fold (1.21 log units) above, and the stated range ends above it.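

In this assay, 4-methylpiperazin-1-yl in place of carbamoyl gives an at least 51-fold lower number from compound 2 to compound 3 (1.70 log units; beyond the scatter), and in place of cyano it gives an at least 51-fold lower number from compound 1 to compound 3 (1.70 log units; beyond the scatter). Compound 3 is thus the only compound shown with a measured number, so the group on this aromatic carbon can separate members of the series. Both steps are minimum sizes, because compound 1 and compound 2 each end at a limit: the limit of > 25000 nM in this assay, at which 2 of the 3 values shown sit.

On these data alone, it remains open whether the lower number follows the non-aromatic ring or its nitrogen atoms. A morpholine or an open-chain dimethylamino group on this carbon would bear on that.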